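Urea-to-benzamide exchange in a pyrazole series with inactive anchors

The source may hold more compounds than are shown below. What is called first, only, known or untested is meant among the compounds shown, and "the series" means these compounds.

Compound 3, `COc1cc(-c2nn(-c3cccc(NC(=O)Nc4cccc(C(F)(F)F)c4)c3)cc2-c2ccncc2)ccc1Cl`, is the reference point. In a functional assay on CCRF-CEM cells (Homo sapiens) for inhibition, read by sulforhodamine B assay, with a stated time of 48 h (on this read-out higher numbers stand for lower toxicity in this test and lower numbers for higher toxicity in this test), compound 3 gives > 50000 nM, which is a limit of the assay and not a number. Compound 1, `O=C(Nc1cccc(-n2cc(-c3ccncc3)c(-c3ccc(Cl)c(O)c3)n2)c1)Nc1cccc(C(F)(F)F)c1`, differs from it by methyl in place of hydrogen on an oxygen on an aromatic ring; compound 1 gives > 32500 nM, again only a limit. Compound 2, `COc1cc(-c2nn(-c3cccc(NC(=O)Nc4cc(C(F)(F)F)cc(C(F)(F)F)c4)c3)cc2-c2ccncc2)ccc1Cl`, carries a second trifluoromethyl; compound 2 gives > 50000 nM, also a limit. The steps a step that the two limits leave unreadable from compound 1 to compound 3 and a step that the two limits leave unreadable from compound 2 to compound 3 therefore cannot be sized, and all three values sit at limits of the assay, as shown by the limit of > 32500 nM in this assay, at which 1 of the 3 values shown sits, and (the limit of > 50000 nM in this assay, at which 2 of the 3 values shown sit).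

Compound 4, `COc1cc(-c2nn(-c3cccc(NC(=O)c4ccccc4)c3)cc2-c2ccncc2)ccc1Cl`, is the next step: phenyl in place of (3-(trifluoromethyl)phenyl)amino on a carbonyl carbon. The urea linkage becomes a benzamide, and the trifluoromethyl is lost with the departing (3-(trifluoromethyl)phenyl)amino group. Among the measured compounds shown here, no measured step touches this change, and the two measured steps that neighbour compound 3 are themselves unreadable, so there is no basis for expecting a move away from the limit in either direction.

Compound 4 is expected to give 50000 nM in this assay, with an estimated range from 20000 nM to 120000 nM. The step expected is a number no higher from compound 3 to compound 4 (the limit leaves the size open), most likely again reported only as a limit.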

Compound 4, concentration lethal to 50% of the cells: > 100000 nM
Compound 4 gave a limit, no number (the forecaster's own chance of this, stated with the estimate: 85%); middle value at least 2.0-fold (0.30 log units) from the limit.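

In this assay compound 4 gives > 100000 nM, a limit of the assay and not a number. Compound 3 gives > 50000 nM, also only a limit, so the step to compound 4 cannot be read. The compounds shown leave open what numerical value, if any, any of them would reach in this assay: the limit of > 100000 nM in this assay, at which 1 of the 4 values shown sits.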